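A larger group on a compound at the limit

This account rests on a few compounds, and the source may have more. Where it says the series, first, only, none or still open, it means among the compounds named here.

Compound 1 `C=C[C@@](C)(/C=C/c1ccc(O)cc1)CC/C=C/C(=O)OCC` and compound 2 `C=C[C@@](C)(/C=C/c1ccc(O)c(C=O)c1)CCC=C(C)C` were both tested in an ADME assay on BJ cells (Homo sapiens) for cytotoxicity, with a stated time of 72 h; on this read-out lower numbers stand for an effect already at smaller amounts and higher numbers for an effect only at larger amounts of compound. Compound 1 gives > 36600 nM, which is a limit and not a number. Compound 2 gives > 36600 nM, which is also a limit. Compound 3 `C=C[C@@](C)(/C=C/c1ccc(O)c(/C=C/c2ccc(F)cc2)c1)CCC=C(C)C` carries 2-(4-fluorophenyl)ethenyl in place of formyl on an aromatic carbon, ortho to a hydroxy group (2-(4-fluorophenyl)ethenyl in place of formyl on an aromatic carbon). Among the compounds with values here, no measured pair shows what such a change does, so only a modest shift towards lower numbers is expected in this assay, possibly none beyond the scatter. The estimated change is an at least 1.4-fold lower number from compound 2 to compound 3 (0.16 log units; that floor lies within the scatter). Compound 3 is expected at 25000 nM, within an estimated range of 8000 nM to 40000 nM.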

Compound 3, half-maximal effective concentration: > 36600 nM
Compound 3 gave a limit, no number; the forecaster's own chance of this, stated with the estimate: 55%; at least 1.4-fold (0.16 log units) between middle value and limit.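

No step can be read from compound 2 to compound 3, as both values are limits and not numbers: the limit of > 36600 nM in this assay, at which 3 of the 3 values shown sit.

The compounds shown leave open whether replacing formyl with 2-(4-fluorophenyl)ethenyl changes the read-out at all, and at what amount any of them would have an effect.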